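What one methoxy may be worth

The compounds below may be only part of what the source reports. "The series", "measured", "known", "first", "only" and "open" are said of these compounds alone.

In a functional assay on HT-29 cells (Homo sapiens) for antiproliferative activity, read by MTT assay, with a stated time of 72 h (on this read-out higher numbers stand for weaker inhibition and lower numbers for stronger inhibition), compound 1 `CCn1ccnc1-c1cc(OC)c(OC)c(OC)c1` gives > 100000 nM, which is a limit of the assay and not a number. Compound 2 `COc1cc(-c2nccn2CC(C)C)cc(OC)c1OC` gives > 100000 nM, again only a limit. Within the data shown here, compound 3 `COc1ccc(-n2ccnc2-c2cc(OC)c(OC)c(OC)c2)cc1[N+](=O)[O-]` gives 600 nM, the only true number so far. Compound 4 `COc1cc(-c2nccn2-c2cccc([N+](=O)[O-])c2)cc(OC)c1OC` carries hydrogen in place of methoxy on an aromatic carbon. Among the measured compounds shown here, the only measured step, a step that the two limits leave unreadable from compound 1 to compound 2, lies elsewhere on the structure and offers no size to carry over. The expectation therefore rests on compound 3 at 600 nM alone, with weaker inhibition thought likelier than stronger. The expected change is a 6.7-fold higher number from compound 3 to compound 4 (0.82 log units; beyond the scatter). Compound 4 is estimated at 4000 nM, within a wide range of 600 nM to 40000 nM.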

Compound 4, half-maximal inhibitory concentration: > 100000 nM
Compound 4: no number, only a limit; the forecaster's own chance of this, stated with the estimate: 15%; at least 25-fold (1.39 log units) between middle value and limit.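

Hydrogen in place of the methoxy ortho to a nitro group gives an at least 160-fold higher number from compound 3 to compound 4 (2.22 log units; beyond the scatter) in this assay. Among these compounds, this is the first step here with a readable size, and it shows that activity can depend heavily on this one position. Compound 4 gives > 100000 nM, which is a limit of the assay and not a number, so the step is only a minimum because the reading stops there: the limit of > 100000 nM in this assay, at which 3 of the 4 values shown sit.

Going by these compounds, whether methoxy itself is required at this position remains open. A hydroxyl, an ethoxy or an amine there could show whether other groups can hold the activity of compound 3.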